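Swapping the sulfur-linked heteroaryl in a cytotoxic amide series

The source may hold more compounds than are shown below. What is called first, only, known or untested is meant among the compounds shown, and "the series" means these compounds.

Measured compounds:
compound 1, `Cn1c(-c2ccc(NC(=O)CSc3nc4cc(Cl)ccc4o3)cc2)nc(-c2ccccc2)c1-c1ccccc1`, 40%
compound 2, `Cc1ccc2oc(SCC(=O)Nc3ccc(-c4nc(-c5ccccc5)c(-c5ccccc5)n4C)cc3)nc2c1`, 40.3%
compound 3, `Cn1c(-c2ccc(NC(=O)CSc3nc4ccccc4s3)cc2)nc(-c2ccccc2)c1-c1ccccc1`, 50.3%

In a functional assay on MCF7 cells (Homo sapiens) for cytotoxicity, read by MTT assay, with a stated time of 24 h, tested at 16 ug/mL (on this read-out lower numbers stand for a weaker effect and higher numbers for a stronger effect at the one concentration tested), compound 2 stands second highest of the three numbers, with compound 1 within the scatter of it and compound 3 a step of a number 10 percentage points higher from compound 2 to compound 3 (within the scatter) away, also within the scatter. Compound 4, `Cn1nnnc1SCC(=O)Nc1ccc(-c2nc(-c3ccccc3)c(-c3ccccc3)n2C)cc1`, differs from compound 2 by 1-methyl-1H-tetrazol-5-yl in place of 5-methyl-1,3-benzoxazol-2-yl on a sulfur. The measured steps that touch the sulfur-linked group are a number 10 percentage points higher from compound 2 to compound 3 (within the scatter) and a number 10.3 percentage points higher from compound 1 to compound 3 (beyond the scatter); neither replaces the bicyclic group with a single five-membered ring, so they bear only loosely. On that basis compound 4 is expected to show a step of a number 5.3 percentage points lower from compound 2 to compound 4 (within the scatter) in this assay, not clearly beyond the scatter. Compound 4 is estimated at 35%, within 15% to 55%.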

Compound 4, a percentage reported as activity, at one concentration (the size of the read-out at that concentration, not a potency): 63.7%
The estimate for compound 4 lay 28.7 percentage points below the measured number; the measured number lies above the stated range.
By their numbers in this assay, from the lowest: compounds 1, 2 and 3 (each within the scatter of the next, the first and the last beyond it); then compound 4.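

On the sulfur whose other neighbour is a saturated chain carbon, 1-methyl-1H-tetrazol-5-yl, a single five-membered aromatic ring, exceeds all three bicyclic groups in this assay: a number 23.4 percentage points higher from compound 2 to compound 4 (beyond the scatter), a number 23.7 percentage points higher from compound 1 to compound 4 (beyond the scatter) and a number 13.4 percentage points higher from compound 3 to compound 4 (beyond the scatter). The largest step among the bicyclic groups was a number 10.3 percentage points higher from compound 1 to compound 3 (beyond the scatter), so this position keeps its effect without the six-membered aromatic ring. Nothing shown here bears on why the number rises. Going by these compounds, it remains open whether the ring's methyl matters, and whether an amine or a carboxylic acid on this sulfur-linked chain would hold the effect.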